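Methyl for amino: what to expect of compound 4

This account rests on a few compounds, and the source may have more. Where it says the series, first, only, none or still open, it means among the compounds named here.

Measured in a functional assay on U2OS cells (Homo sapiens) for cytotoxicity, read by MTT assay, with a stated time of 48 h (on this read-out lower numbers stand for stronger inhibition and higher numbers for weaker inhibition), so far
compound 1 `Fc1cccc(-c2nc(Nc3ccc(Cl)cc3)c3cc(F)ccc3n2)c1` gives 38400 nM as a number
compound 2 `Fc1cccc(-c2nc(Nc3ccccc3Cl)c3cc(F)ccc3n2)c1` gives > 50000 nM as a limit
compound 3 `Nc1ccc(Nc2nc(-c3cccc(F)c3)nc3ccc(F)cc23)cc1` gives 44200 nM as a number

Compound 3 gives 44200 nM and lies within the scatter of compound 1 at 38400 nM on this read-out. Compound 2 gives > 50000 nM which is a limit and not a number. Within the data shown here, only two true numbers are therefore available, and they cannot be told apart.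

Compound 4 `Cc1ccc(Nc2nc(-c3cccc(F)c3)nc3ccc(F)cc23)cc1` keeps the shared core of compound 3 and carries methyl in place of amino on an aromatic carbon, para to a large group (methyl in place of amino on an aromatic carbon). The closest measured exchange is amino in place of chloro on an aromatic carbon, which gave a 1.2-fold higher number from compound 1 to compound 3 (0.06 log units; within the scatter) in this assay without leaving the scatter. The two steps involving the limit, an at least 1.3-fold higher number from compound 1 to compound 2 (0.11 log units; that floor lies within the scatter) and an at least 1.1-fold lower number from compound 2 to compound 3 (0.05 log units; that floor lies within the scatter), offer only floors that also lie within the scatter. Among the measured compounds shown here, no measured compound carries methyl at this place, so the expectation rests on chloro and amino alone. No step beyond the scatter is expected, in either direction. The expected step is a 1.2-fold lower number from compound 3 to compound 4 (0.09 log units; within the scatter) and this estimate stays small. For compound 4 the estimated value is 36000 nM with an expected range of 15000 nM to 60000 nM in this assay once it is measured.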

Compound 4, half-maximal inhibitory concentration: > 50000 nM
Compound 4 was reported as a limit; the forecaster's own chance of this, stated with the estimate: 25%; middle value at least 1.3-fold (0.14 log units) away from the limit.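

In this assay compound 4 gives > 50000 nM, which is a limit and not a number. Methyl is thus the only group on this aromatic carbon, para to a large group, that gave no number, whereas amino and chloro each gave one. The change shows no gain in cytotoxicity, but the size of any loss stays unresolved: the exchange for amino gave an at least 1.1-fold higher number from compound 3 to compound 4 (0.05 log units; that floor lies within the scatter) and the exchange for chloro gave an at least 1.3-fold higher number from compound 1 to compound 4 (0.11 log units; that floor lies within the scatter). The step between compound 2 and compound 4 cannot be read, and the series now rests heavily on one limit: the limit of > 50000 nM in this assay, at which 2 of the 4 values shown sit.

Going by these compounds, how far compound 4 lies from compound 1 and compound 3 therefore remains open, as does whether any group at this place can move the read-out beyond the scatter. A hydroxyl, a carboxylic acid or a longer chain such as ethyl on the same aromatic carbon would test whether this position matters at all in this assay and whether a value clearly apart from the others can be obtained there.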